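A few compounds are considered here, and "the series" means these few. Any claim that something is new, unique, unknown or untested is made for them only; others in the source may bear on it.

Working notes on the series, cytotoxicity read-out. In an ADME assay on HeLa cells (Homo sapiens) for cytotoxicity, read by crystal violet staining, with a stated time of 72 h (a higher number here means that more compound is tolerated, a lower number that less compound is tolerated), compound 1 `CCOC(=O)c1cc(CCCOc2ccc(-c3noc(C(F)(F)F)n3)cc2)on1` gives > 100000 nM, which is a limit and not a number. Compound 2 `CCOC(=O)c1cc(CCCOc2ccc(-c3noc(C(F)(F)F)n3)cc2OC)on1` gives > 100000 nM, again only a limit. For the measured compounds named here, compound 3 `CN(C)C(=O)c1cc(CCCOc2ccc(-c3noc(C(F)(F)F)n3)cc2)on1` gives 28000 nM, the one actual number so far.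

The next compound, compound 4 `COc1cc(-c2noc(C(F)(F)F)n2)ccc1OCCCc1cc(C(=O)N(C)C)no1`, is compound 3 with methoxy in place of hydrogen on an aromatic carbon, ortho to a large group and meta to a 5-(trifluoromethyl)-1,2,4-oxadiazol-3-yl group: methoxy in place of hydrogen on an aromatic carbon.

Going by the values given here, two measured steps bear on this. The same replacement appears in a step that the two limits leave unreadable from compound 1 to compound 2. That step gives no size because of the limit of > 100000 nM in this assay, at which 2 of the 3 values shown sit. The other step is a change elsewhere in the molecule, dimethylamino in place of ethoxy on a carbonyl carbon, and it is an at least 3.5-fold lower number from compound 1 to compound 3 (0.55 log units; beyond the scatter). It places compound 3 on a readable number but says nothing about methoxy. With no measured size for the methoxy change, no step beyond the scatter is expected in this assay, and no direction can be favoured. The expected step is a 1.1-fold higher number from compound 3 to compound 4 (0.03 log units; within the scatter). Compound 4 is estimated at 30000 nM, with an expected range from 13000 nM to 70000 nM.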

Compound 4, half-maximal cytotoxic concentration: 68000 nM
The estimate for compound 4 lay 2.3-fold (0.36 log units) below the measured number; measured number inside the range.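

In this assay, methoxy in place of hydrogen on an aromatic carbon, ortho to a large group, now has a readable size: a 2.4-fold higher number from compound 3 to compound 4 (0.39 log units; beyond the scatter) on the core with dimethylamino on the carbonyl carbon. For the compounds shown here, the same replacement on the ethoxy core could not be read, so this is the first sign that the position responds at all, and the direction is towards more compound tolerated. The dimethylamino change, seen again on the methoxy core, gives an at least 1.4-fold lower number from compound 2 to compound 4 (0.16 log units; that floor lies within the scatter) as its second reading, and that reading alone does not establish a step beyond the scatter; set beside the first, it leaves the comparison undecided: the same change on two cores in this assay, an at least 3.5-fold lower number (0.55 log units; beyond the scatter) from compound 1 to compound 3 and an at least 1.4-fold lower number (0.16 log units; that floor lies within the scatter) from compound 2 to compound 4; the limit leaves it open whether they differ.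

Whether methoxy has a similar effect on the ethoxy core remains unreadable, and the ceiling of the assay limits both that question and the comparison of the two dimethylamino steps: the limit of > 100000 nM in this assay, at which 2 of the 4 values shown sit. Also open, as far as these compounds go, is whether the step is particular to methoxy or extends to a hydroxy group or a fluorine at the same position, and how a carboxylic acid on the carbonyl carbon would read on either core.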